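The source may report more compounds than this note shows. Statements on the series, on what has been measured and on what is new or still open speak of the compounds shown alone.

Compound 1 `O=c1cc(NCc2cccc(F)c2)sc2c([N+](=O)[O-])cc(C(F)(F)F)cc12` was examined in an ADME assay on Vero cells (Chlorocebus sabaeus) for cytotoxicity, read by MTT assay, with a stated time of 48 h; a higher number here means a weaker inhibitor, a lower number a stronger inhibitor. In this assay compound 1 gives > 64 ug/mL, which is a limit of the assay and not a number. Compound 3 `C[C@H]1COC2(CCN(c3nc(=O)c4cc(C(F)(F)F)cc([N+](=O)[O-])c4s3)CC2)O1` likewise gives only > 64 ug/mL, a limit. Compound 2 `O=c1nc(NCc2ccc3c(c2)OCCO3)oc2c([N+](=O)[O-])cc(C(F)(F)F)cc12` gives 25.3 ug/mL. Compound 1 therefore stands at the limit of > 64 ug/mL in this assay, at which 2 of the 3 values shown sit. Compound 4 `O=c1cc(NC2CCCCC2)sc2c([N+](=O)[O-])cc(C(F)(F)F)cc12` has not yet been measured in this assay; it differs from compound 1 by cyclohexyl in place of 3-fluorobenzyl on a nitrogen on an aromatic ring. Going by the values given here, no measured pair of compounds separated by a single change is available here, so no step of this kind can be read from the data. The expected step that the limit leaves unreadable from compound 1 to compound 4 is none beyond the scatter. Compound 4 is expected to give 70 ug/mL, with a range from 32 ug/mL to 150 ug/mL, most likely reported again only as a limit.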

Compound 4, half-maximal inhibitory concentration: > 64 ug/mL
Compound 4: only a limit was reported; the forecaster's own chance of this, stated with the estimate: 70%; the middle value does not contradict the limit.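

Compound 1 and compound 4 both give only a limit in this assay, so no step between them can be read: the limit of > 64 ug/mL in this assay, at which 3 of the 4 values shown sit.

The compounds shown leave open how cyclohexyl and 3-fluorobenzyl compare on that nitrogen, as neither compound gives a number.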